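This account rests on a few compounds, and the source may have more. Where it says the series, first, only, none or still open, it means among the compounds named here.

Compound 1 `O=C(Nc1cccc(-n2cc(-c3ccncc3)c(-c3ccc(Cl)c(O)c3)n2)c1)Nc1cccc(C(F)(F)F)c1` — 1340 nM
Compound 2 `COc1cc(-c2nn(-c3cccc(NC(=O)Nc4ccc(Cl)c(C(F)(F)F)c4)c3)cc2-c2ccncc2)ccc1Cl` — 870 nM

Both compounds were tested in a functional assay on RPMI-8226 cells (Homo sapiens) for inhibition, read by sulforhodamine B assay, with a stated time of 48 h; a lower number here means a stronger inhibitor, a higher number a weaker inhibitor. Compound 2 gives 870 nM and compound 1 gives 1340 nM; of the two numbers that of compound 2 is the lower, but the gap between them lies within the scatter, so the two cannot be told apart. Compound 3 `O=C(Nc1cccc(-n2cc(-c3ccncc3)c(-c3ccc(Cl)c(O)c3)n2)c1)Nc1ccc(Cl)c(C(F)(F)F)c1` differs from compound 2 in one place: hydrogen in place of methyl on an oxygen on an aromatic ring, that is, methoxy becomes hydroxy and 4-chloro-3-methoxyphenyl becomes 4-chloro-3-hydroxyphenyl. Among the compounds with values here, compound 1 already carries the hydroxy version of this ring, though with a different group on the urea, so no step between measured compounds isolates this change. Given that compound 1 and compound 2 sit within the scatter of each other, the change is expected to move the number little, in no definite direction, with a 1.1-fold higher number from compound 2 to compound 3 (0.04 log units; within the scatter) expected to stay within the scatter. Compound 3 is estimated at 950 nM in this assay, within a range of 350 nM to 2600 nM.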

Compound 3, half-maximal inhibitory concentration: 580 nM
For compound 3 the middle estimate is 1.6-fold (0.21 log units) above the measured one; the measured number falls inside the stated range.
By their numbers in this assay, from the lowest: compounds 3, 2 and 1 (each within the scatter of the next, the first and the last beyond it).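

In this assay, swapping methoxy for hydroxy on this ring gives a step that stays within the scatter (a 1.5-fold lower number from compound 2 to compound 3 (0.18 log units; within the scatter)), so at this position on the oxygen, a methyl and a hydrogen cannot be told apart in this pair. The other new pair shows a change that can be read: chloro in place of hydrogen on an aromatic carbon, with the hydroxy ring held constant, gives a modest step beyond the scatter (a 2.3-fold lower number from compound 1 to compound 3 (0.36 log units; beyond the scatter)). No measurement at hand explains either step.

The compounds shown leave open whether a longer chain on the same oxygen, such as ethoxy, or an amine in place of the hydroxy would move the number beyond the scatter. They also leave open whether another halogen, such as fluoro or bromo, in place of the chloro would give a step of similar size, and whether the chloro step would look the same alongside 4-chloro-3-methoxyphenyl.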